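Compound 4 after three readings at the limit

The source may report more compounds than this note shows. Statements on the series, on what has been measured and on what is new or still open speak of the compounds shown alone.

Compound 1 (`COc1ccc(C=C2C(=O)N(c3ccc(Cl)cc3)N(c3ccc(Cl)cc3)C2=O)cc1`), compound 2 (`COc1ccc(C=C2C(=O)N(c3ccc(Cl)cc3)N(c3ccc(Cl)cc3)C2=O)cc1OC`) and compound 3 (`O=C1C(=Cc2ccc(Cl)cc2Cl)C(=O)N(c2ccc(Cl)cc2)N1c1ccc(Cl)cc1`) were all tested in a functional assay on MGC-803 cells (Homo sapiens) for cytotoxicity, read by MTT assay, with a stated time of 72 h; a higher number here means a weaker inhibitor, a lower number a stronger inhibitor. Compound 1 gives > 128000 nM, which is a limit of the assay. Compound 2 gives > 128000 nM, again a limit. Compound 3 gives > 128000 nM, also a limit, so it has no number of its own. For the measured compounds named here, the series so far comes down to the limit of > 128000 nM in this assay, at which 3 of the 3 values shown sit.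

Compound 4 (`O=C1C(=Cc2c[nH]c3ccccc23)C(=O)N(c2ccc(Cl)cc2)N1c1ccc(Cl)cc1`) carries 1H-indol-3-yl in place of 2,4-dichlorophenyl on a double-bonded chain carbon bound to a double-bonded ring carbon. Two measured changes at that same place bear on this, a step that the two limits leave unreadable from compound 1 to compound 3 and a step that the two limits leave unreadable from compound 2 to compound 3, and the methoxy change adds a step that the two limits leave unreadable from compound 1 to compound 2. None of them has a readable size, so they offer no measured guide. Little movement in this assay is therefore expected, and any movement would be toward a stronger inhibitor. The expected change is an at least 1.4-fold lower number from compound 3 to compound 4 (0.15 log units; that floor lies within the scatter). Compound 4 is estimated at 90000 nM, with an expected range from 15000 nM to 128000 nM.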

Compound 4, half-maximal inhibitory concentration: 21800 nM
Estimate against measurement, compound 4: 4.1-fold (0.62 log units) above, within the range that was stated.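

For the compounds shown here, at the place on a double-bonded chain carbon bound to a double-bonded ring carbon, 1H-indol-3-yl gives the first reading in this assay that has a number of its own, and the change can now be bounded: an at least 5.8-fold lower number from compound 3 to compound 4 (0.76 log units; beyond the scatter), an at least 5.8-fold lower number from compound 2 to compound 4 (0.76 log units; beyond the scatter) and an at least 5.8-fold lower number from compound 1 to compound 4 (0.76 log units; beyond the scatter). Each of these is a floor rather than a true size, all lie beyond the scatter, and the steps among compound 1, compound 2 and compound 3 cannot be read. Compound 4 is the only compound shown that stands off the limit: the limit of > 128000 nM in this assay, at which 3 of the 4 values shown sit.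

The compounds shown leave open whether the reading follows the hydrogen on the indole nitrogen or the second ring alone. A 1-methyl-1H-indol-3-yl or a naphthalen-2-yl group at this place would separate the two.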